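The source may hold more compounds than are shown below. What is called first, only, known or untested is meant among the compounds shown, and "the series" means these compounds.

Measured so far in an ADME assay for permeability, using PAMPA, with a stated time of 4 h; a lower number here means that the compound crosses the layer more slowly, a higher number that the compound crosses the layer faster:

- compound 1 `Cn1c(COc2cccc(C(=O)O)c2)nc2ccc(Oc3ccc(F)cn3)cc21`: 4.7 10^-6 cm/s
- compound 2 `Cc1ccc(Oc2ccc3nc(COc4cccc(C(=O)O)c4)n(C)c3c2)nc1C`: 7.7 10^-6 cm/s

In this assay, among the measured compounds shown here, compound 2 gives 7.7 10^-6 cm/s, which lies within the scatter of the only other measured value, so the two compounds cannot be ranked. Compound 3 `Cc1ccc(C)c(Oc2ccc3nc(COc4cccc(C(=O)O)c4)n(C)c3c2)n1` has the same atoms as compound 2, joined differently: 3,6-dimethylpyridin-2-yl stands in place of 5,6-dimethylpyridin-2-yl on an oxygen on an aromatic ring (3,6-dimethylpyridin-2-yl in place of 5,6-dimethylpyridin-2-yl on an oxygen on an aromatic ring). For the measured compounds named here, only one measured step bears on this place, and it is a 1.6-fold higher number from compound 1 to compound 2 (0.21 log units; within the scatter). Going by the values given here, that step exchanges a different group, and no measured pair shows a change of this kind. No step beyond the scatter is therefore expected in this assay. The expected step is a 1.0-fold lower number from compound 2 to compound 3 (0.01 log units; within the scatter). For compound 3 the estimated value is 7.5 10^-6 cm/s, with an expected range from 3.8 10^-6 cm/s to 15 10^-6 cm/s.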

Compound 3, apparent permeability in the ADME assay: 11 10^-6 cm/s
Compound 3: the middle estimate sits 1.5-fold (0.17 log units) below what was measured; the range from low to high includes it.
By their numbers in the ADME assay, from the lowest: compounds 1, 2 and 3 (each within the scatter of the next, the first and the last beyond it).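

In the ADME assay, rearranging the same atoms gives a 1.4-fold higher number from compound 2 to compound 3 (0.15 log units; within the scatter), so this change of methyl placement on the ring carried by the oxygen does not separate the two isomers there. Among the compounds shown here, replacing 5-fluoropyridin-2-yl with 3,6-dimethylpyridin-2-yl gives a 2.3-fold higher number from compound 1 to compound 3 (0.37 log units; beyond the scatter), the first step at this position in this assay to pass beyond the scatter. In a physicochemical assay for solubility, read by HPLC, measured as thermodynamic solubility, with a stated time of 4 h, at pH 6.8 (on this read-out lower numbers stand for lower solubility and higher numbers for higher solubility), compound 2 gives 190 ug/mL and compound 3 gives 85 ug/mL. The isomer change does register in the physicochemical assay, where the pair separates: the measured solubility of compound 2, 190 ug/mL, and of compound 3, 85 ug/mL, a 2.2-fold lower number (0.35 log units; beyond the scatter)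

The compounds shown leave open whether a methoxy group or a chlorine atom at this ring, in place of the methyl groups, would keep the reading of compound 3 in the ADME assay. For the compounds shown here, only the pair of compound 2 and compound 3 appears here in both assays, so whether the two read-outs diverge for other groups at this position remains unknown.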